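One More Chloro on a Compound at the Limit

This account rests on a few compounds, and the source may have more. Where it says the series, first, only, none or still open, it means among the compounds named here.

In an ADME assay on HaCaT cells (Homo sapiens) for cytotoxicity, read by MTT assay, with a stated time of 48 h (a higher number here means a weaker inhibitor, a lower number a stronger inhibitor), compound 1 `Clc1cc2nc(-c3cn(-c4ccccc4)nc3-c3ccccc3)[nH]c2cc1Cl` gives 29700 nM and compound 2 `Fc1ccc(-c2nn(-c3ccccc3)cc2-c2nc3cc(Cl)c(Cl)cc3[nH]2)cc1` gives 44600 nM as measured numbers. Compound 3 `Clc1ccc(-c2nn(-c3ccccc3)cc2-c2nc3cc(Cl)ccc3[nH]2)cc1` gives > 50000 nM as a limit of the test and not a number. Compound 4 `Clc1ccc(-c2nn(-c3ccccc3)cc2-c2nc3cc(Cl)c(Cl)cc3[nH]2)cc1` is compound 3 with chloro in place of hydrogen on an aromatic carbon and no other change. Among the measured compounds shown here, no measured step shows this change itself. For the measured compounds named here, the one measured step, fluoro in place of hydrogen, is a 1.5-fold higher number from compound 1 to compound 2 (0.18 log units; within the scatter) and so gives no sign of a large effect. Compound 2 already carries the entering chloro and gives 44600 nM as a number, so a small step to a lower number is expected, not clearly beyond the scatter. The expected step is an at least 1.2-fold lower number from compound 3 to compound 4 (0.09 log units; that floor lies within the scatter) on this estimate. Compound 4 is expected at 40000 nM with an estimated range from 22000 nM to 75000 nM in this test.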

Compound 4, half-maximal inhibitory concentration: > 50000 nM
Compound 4: a limit, no number; the forecaster's own chance of this, stated with the estimate: 35%; at least 1.2-fold (0.09 log units) between middle value and limit.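

A second chloro at this aromatic carbon does not bring a measured number into this assay, and compound 4 is a limit of the test, not a number. Fluoro changed to chloro gives an at least 1.1-fold higher number from compound 2 to compound 4 (0.04 log units; that floor lies within the scatter) as a floor only, and chloro in place of hydrogen on the para ring carbon of the phenyl gives an at least 1.6-fold higher number from compound 1 to compound 4 (0.22 log units; that floor lies within the scatter) as a floor too. The steps that start from compound 3 cannot be read, since both compounds end at the same limit: the limit of > 50000 nM in this assay, at which 2 of the 4 values shown sit.

Open, going by these compounds, is whether an amine or a carboxylic acid at this carbon, ortho to the chloro group, would give a number under that limit.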